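Dropping an Isopropyl Group: What to Expect for Compound 4

The source may hold more compounds than are shown below. What is called first, only, known or untested is meant among the compounds shown, and "the series" means these compounds.

Three compounds have been measured in a functional assay on ECa-109 cells (Homo sapiens) for inhibition, read by MTT assay, with a stated time of 72 h; on this read-out higher numbers stand for weaker inhibition and lower numbers for stronger inhibition:
Compound 1, `CC(C)c1ccc(-c2nc(SCc3cn(CC(=O)NC(=O)Nc4ccccn4)nn3)nc(Nc3ccccc3F)c2C#N)cc1`, gives 15500 nM.
Compound 2, `COc1ccc(Nc2nc(SCc3cn(CC(=O)NC(=O)Nc4ccccn4)nn3)nc(-c3ccc(C(C)C)cc3)c2C#N)cc1`, gives 5420 nM.
Compound 3, `Cc1ccc(Nc2nc(SCc3cn(CC(=O)NC(=O)Nc4ccccn4)nn3)nc(-c3ccc(C(C)C)cc3)c2C#N)cc1`, gives 6700 nM.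

Compound 3 stands second highest of the three numbers. Its nearest neighbour is compound 2, and that gap, a 1.2-fold higher number from compound 2 to compound 3 (0.09 log units; within the scatter), lies within the scatter, so the two cannot be told apart. The largest gaps, a 2.9-fold lower number from compound 1 to compound 2 (0.46 log units; beyond the scatter) and a 2.3-fold lower number from compound 1 to compound 3 (0.36 log units; beyond the scatter), are modest and come from swapping the 2-fluorophenyl on the nitrogen for a 4-methoxyphenyl or 4-methylphenyl.

Compound 4, `Cc1ccc(Nc2nc(SCc3cn(CC(=O)NC(=O)Nc4ccccn4)nn3)nc(-c3ccccc3)c2C#N)cc1`, is made from compound 3 by hydrogen in place of isopropyl on an aromatic carbon. For the measured compounds named here, none of the measured steps touches this part of the molecule, so there is no direct guide. The measured steps elsewhere were small, and nothing in the data points one way or the other, so the expected step of a 1.2-fold higher number from compound 3 to compound 4 (0.08 log units; within the scatter) is about none beyond the scatter, with a wide range. Compound 4 is estimated at 8000 nM, between 2500 nM and 30000 nM.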

Compound 4, half-maximal inhibitory concentration: 24600 nM
Estimate against measurement, compound 4: 3.1-fold (0.49 log units) below; the measured number falls inside the stated range.
By their numbers in this assay, from the lowest: compounds 2 and 3 (each within the scatter of the next); then compounds 1 and 4 (each within the scatter of the next).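

Replacing the isopropyl group with hydrogen, which turns the 4-isopropylphenyl into a plain phenyl, gives a 3.7-fold higher number from compound 3 to compound 4 (0.56 log units; beyond the scatter) in this assay. This is the first step shown at this position, and it shows that the group on this aromatic carbon affects the read-out, with inhibition weakening when the isopropyl group is lost. Nothing available explains this shift.

With a single pair at this position, the compounds shown leave open whether a methyl, an ethyl, a tert-butyl or an amine on the same carbon would keep the inhibition seen with isopropyl. They also leave open whether losing the isopropyl group has a similar effect when the nitrogen carries a 4-methoxyphenyl or 2-fluorophenyl group.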